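The source may hold more compounds than are shown below. What is called first, only, known or untested is meant among the compounds shown, and "the series" means these compounds.

Of the compounds shown here, two have so far been measured in a functional assay on MCF7 cells (Homo sapiens) for cytotoxicity, read by MTT assay, with a stated time of 48 h; on this read-out higher numbers stand for weaker inhibition and lower numbers for stronger inhibition. Compound 1, `COc1cc(N2C(=S)SCC2(O)c2ccc(Cl)cc2Cl)cc(OC)c1OC`, gives 9.6 ug/mL in this assay. Compound 2, `COc1cc(-n2c(-c3ccccc3)csc2=S)cc(OC)c1OC`, shares part of its structure with compound 1 but has a different core. For compound 2 this assay reports no number, only a limit of > 100 ug/mL. That puts compound 2 at the limit of > 100 ug/mL in this assay, at which 1 of the 2 values shown sits, the higher of the two values shown, which on this read-out means the weaker inhibition. Compound 3, `COc1cc(-n2c(-c3ccc(-c4ccccc4)cc3)csc2=S)cc(OC)c1OC`, differs from compound 2 in a single place: phenyl in place of hydrogen on an aromatic carbon. For the measured compounds named here, no measured pair shows what such a change does in this assay, so nothing beyond compound 2 itself supports a forecast. The expected step is an at least 1.2-fold lower number from compound 2 to compound 3 (0.09 log units; that floor lies within the scatter), most likely none beyond the usual scatter. Compound 3 is accordingly estimated at 80 ug/mL, between 25 ug/mL and 250 ug/mL, with a real chance that this assay again returns only a limit.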

Compound 3, half-maximal inhibitory concentration: 45.3 ug/mL
Beside the measured number, compound 3's estimate is 1.8-fold (0.25 log units) above it; the range from low to high includes it.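

In this assay, phenyl in place of hydrogen on this aromatic carbon, para to a large group, gives an at least 2.2-fold lower number from compound 2 to compound 3 (0.34 log units; beyond the scatter), so this position accepts a whole extra ring and the change goes with stronger inhibition. Compound 2 has a limit rather than a number, so the size of the step is known only as a floor: the limit of > 100 ug/mL in this assay, at which 1 of the 3 values shown sits. Compound 1 differs from both in more than one place, so it adds nothing to this comparison.

One change at one position cannot show whether the gain needs an aromatic ring or would follow from any added group. A methyl group, an amine or a carboxylic acid on the same carbon would help separate these possibilities, and the compounds shown leave that question open.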